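Cyano to nitro on compound 3

The source may hold more compounds than are shown below. What is called first, only, known or untested is meant among the compounds shown, and "the series" means these compounds.

Of the compounds shown here, three have been measured so far in a functional assay on VCaP cells (Homo sapiens) for antiproliferative activity, read by propidium iodide staining, with a stated time of 96 h (a lower number here means a stronger inhibitor, a higher number a weaker inhibitor), and all of them give high numbers. Compound 1 (`CC(O)(COc1ccccc1OC(F)(F)F)C(=O)Nc1ccc(S(F)(F)(F)(F)F)cc1`) reads 9700 nM there. Compound 2 (`CC(O)(COc1ccc(C#N)cc1)C(=O)Nc1cccc(S(F)(F)(F)(F)F)c1`) reads 26600 nM on the same scale. Compound 3 (`CC(O)(CS(=O)(=O)c1ccc(S(F)(F)(F)(F)F)cc1)C(=O)Nc1ccc(C#N)cc1C(F)(F)F`) comes in at 43000 nM and shares the weak end of this small set with compound 2, the two lying within the scatter of each other, while compound 1 has a lower number beyond the scatter.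

Compound 4 (`CC(O)(CS(=O)(=O)c1ccc(S(F)(F)(F)(F)F)cc1)C(=O)Nc1ccc([N+](=O)[O-])cc1C(F)(F)F`) keeps the whole of compound 3 except for one group. It has nitro in place of cyano on an aromatic carbon, meta to a trifluoromethyl group and para to a large group (nitro in place of cyano on an aromatic carbon). Among the compounds with values here, none of the measured compounds differ from each other in only one place, so the data do not directly show what such a swap does. The expectation therefore rests on compound 3 at 43000 nM as its anchor, and no step beyond the scatter is expected in this assay for this change. The expected size is a 1.3-fold lower number from compound 3 to compound 4 (0.13 log units; within the scatter) as an estimate, which stays within the scatter. For compound 4 the estimated value is 32000 nM with an expected range from 13000 nM to 75000 nM in all.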

Compound 4, half-maximal inhibitory concentration: 28600 nM
Compound 4: middle estimate off by 1.1-fold (0.05 log units), on the high side; measured number inside the range.
By their numbers in this assay, from the lowest: compound 1; then compounds 2, 4 and 3 (each within the scatter of the next).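

Within the data shown here, compound 3 and compound 4 form the first pair in this set that differs in only one place, giving the first direct reading of a change on this aromatic carbon, meta to a trifluoromethyl group and para to a large group. In this assay, nitro in place of cyano gives a 1.5-fold lower number from compound 3 to compound 4 (0.18 log units; within the scatter), a step within the scatter, so the assay does not separate these two groups at this position. No measurement shown here offers an explanation for this result or ties it to a property of either group.

Cyano and nitro are the only groups shown at this carbon, so it remains open whether another group there, such as an amine, a carboxylic acid or a plain hydrogen, would shift the number beyond the scatter. It is also open whether nitro in place of cyano would read the same way on a different remainder of the molecule, as the other compounds shown form no such pair.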